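Replacing the azepane of compound 1 with a phenylpiperazine

This account rests on a few compounds, and the source may have more. Where it says the series, first, only, none or still open, it means among the compounds named here.

Of the compounds shown here, three sharing a common core have been measured in an assay on CHO cells for antagonist activity at transient receptor potential cation channel subfamily V member 1 (Homo sapiens), read by FLIPR; a higher number here means a weaker inhibitor, a lower number a stronger inhibitor. Compound 1, `CC(C(=O)NCc1ccc(C(F)(F)F)cc1N1CCCCCC1)c1ccc(NS(C)(=O)=O)c(F)c1`, gives 1.6 nM. Compound 2, `CC(C(=O)NCc1ccc(C(F)(F)F)cc1N1CCC(Cc2ccccc2)CC1)c1ccc(NS(C)(=O)=O)c(F)c1`, gives 1.4 nM, and compound 3, `CC(C(=O)NCc1ccc(C(F)(F)F)cc1N1CCC(Cc2ccc(F)cc2)CC1)c1ccc(NS(C)(=O)=O)c(F)c1`, gives 0.4 nM. Compound 1 thus has the highest of the three numbers; its gap to compound 2 lies within the scatter, while its gap to compound 3 lies beyond it, so only compound 3 can be said to be the stronger inhibitor of the three.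

Within the data shown here, the one step that can be read between neighbours is a 3.5-fold lower number from compound 2 to compound 3 (0.54 log units; beyond the scatter), and it concerns a change on the pendant aromatic ring rather than the saturated ring attached to the core.

Compound 4, `CC(C(=O)NCc1ccc(C(F)(F)F)cc1N1CCN(c2ccccc2)CC1)c1ccc(NS(C)(=O)=O)c(F)c1`, differs from compound 1 by 4-phenylpiperazin-1-yl in place of azepan-1-yl on an aromatic carbon. Among the measured compounds shown here, no measured step covers this kind of exchange. Compound 1 and compound 2, which carry an azepan-1-yl and a benzyl-bearing piperidine on that carbon, give numbers within the scatter of each other, which suggests that this position tolerates a larger saturated ring bearing an aromatic group without a clear shift.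

Compound 4 is therefore expected to give 1.5 nM, with a range from 0.4 nM to 6 nM. The step of a 1.1-fold lower number from compound 1 to compound 4 (0.03 log units; within the scatter) is expected to stay within the scatter.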

Compound 4, inhibition constant: 2 nM
For compound 4 the middle estimate is 1.3-fold (0.12 log units) below the measured one; the measured number falls inside the stated range.
By their numbers in this assay, from the lowest: compound 3; then compounds 2, 1 and 4 (each within the scatter of the next).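

In this assay, the exchange at this aromatic carbon, ortho to a large group and meta to a trifluoromethyl group, gives a 1.3-fold higher number from compound 1 to compound 4 (0.10 log units; within the scatter), even though 4-phenylpiperazin-1-yl has more heavy atoms than azepan-1-yl. Compound 4 is also the first of these compounds with two hetero atoms in the saturated ring at this place, and neither that second ring nitrogen nor the six-membered aromatic ring on it shifts the number beyond the scatter relative to compound 1. Nothing available here explains why the number holds across this exchange.

The compounds shown leave open whether a fluoro on the phenyl ring of the 4-phenylpiperazin-1-yl group would give a step like a 3.5-fold lower number from compound 2 to compound 3 (0.54 log units; beyond the scatter), since that step was seen only on the benzyl-bearing piperidine, and whether a chloro or methoxy group there would do the same. As far as these compounds go, it also remains open how the number would respond if that phenyl ring gave way to an acetyl or methyl group on the second ring nitrogen, or if a morpholine took the place of the whole group.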